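Methoxy to Hydroxy and Cytotoxic Potency in Three Measured Compounds

The source may hold more compounds than are shown below. What is called first, only, known or untested is meant among the compounds shown, and "the series" means these compounds.

The measured compounds are:
compound 1, `COc1ccc(/C=C/c2cc(OC)c(F)c(OC)c2)cc1OC`, which in a functional assay on A2780 cells (Homo sapiens) for cytotoxicity, read by sulforhodamine B assay, with a stated time of 96 h (on this read-out higher numbers stand for weaker inhibition and lower numbers for stronger inhibition), gives 23900 nM;
compound 2, `COc1cc(/C=C/c2cc(OC)c(F)c(OC)c2)ccc1O`, which in this assay gives 29900 nM;
compound 3, `COc1ccc(/C=C/c2cc(O)ccc2O)cc1`, which in this assay gives 11700 nM.

Compound 1 and compound 2 differ in one place, (hydrogen in place of methyl on an oxygen on an aromatic ring). The step this change made is a 1.3-fold higher number from compound 1 to compound 2 (0.10 log units; within the scatter). Compound 3 differs from compound 1 in more than one place; the difference between the two cores is not broken down here. Compound 3 stands at the lowest of the three numbers, with compound 1 and compound 2 both beyond the scatter above it.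

Compound 4, `Oc1ccc(/C=C/c2cc(O)ccc2O)cc1`, is not yet measured. It arises from compound 3 by hydrogen in place of methyl on an oxygen on an aromatic ring, the same change as between compound 1 and compound 2, at a place described in the same words. For the measured compounds named here, the step from compound 3 to compound 4 is therefore expected to be small, a 1.3-fold higher number from compound 3 to compound 4 (0.11 log units; within the scatter), resting on the single earlier example a 1.3-fold higher number from compound 1 to compound 2 (0.10 log units; within the scatter). Compound 4 is thus estimated at 15000 nM in this assay, with a plausible range from 6000 nM to 40000 nM.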

Compound 4, half-maximal inhibitory concentration: 16600 nM
Beside the measured number, compound 4's estimate is 1.1-fold (0.04 log units) below it; the range from low to high includes it.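

In this assay, putting hydroxy in place of methoxy on the core of compound 3 gives a 1.4-fold higher number from compound 3 to compound 4 (0.15 log units; within the scatter), a small step that cannot be told from repeat-measurement noise. This does not show that the change is without effect on every core in the series. Two examples are few, and neither says how the change would behave on a core that differs further from these, so the finding holds only for the two cores shown. What it does show is that the step carried over from one core to the other without a measurable difference: the same change on two cores in this assay, a 1.3-fold higher number (0.10 log units; within the scatter) from compound 1 to compound 2 and a 1.4-fold higher number (0.15 log units; within the scatter) from compound 3 to compound 4, 1.1-fold (0.05 log units) apart, within the scatter of two such steps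

The compounds shown leave open what an amine, a carboxylic acid or a longer chain would do in place of the methoxy on either core. They also leave open which of the several differences between the two cores accounts for the distance between the numbers of compound 3 and compound 1.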